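The source may report more compounds than this note shows. Statements on the series, on what has been measured and on what is new or still open speak of the compounds shown alone.

Three anilides built on one shared core have been measured in a functional assay (Cavia porcellus) with sulfonylurea receptors; K-ATP channels (Homo sapiens) as the target; a lower number here means a stronger inhibitor, a higher number a weaker inhibitor. Compound 1 `CC(O)(C(=O)Nc1ccc(S(=O)(=O)c2ccccc2)c(F)c1)C(F)(F)F` gives 1800 nM. Compound 2 `CC(O)(C(=O)Nc1ccc(S(=O)(=O)c2cccc(F)c2)cc1)C(F)(F)F` gives 3400 nM. Compound 3 `CC(O)(C(=O)Nc1ccc(S(=O)(=O)c2ccccc2)c(C#N)c1)C(F)(F)F` gives 3800 nM. Compound 2 thus stands second highest of the three, within the scatter of compound 3 and of compound 1 alike. Among the compounds with values here, the only single-place step among them, a 2.1-fold higher number from compound 1 to compound 3 (0.32 log units; beyond the scatter), alters the ring bearing the amide, not the ring on the sulfonyl sulfur. Compound 4 `CC(O)(C(=O)Nc1ccc(S(=O)(=O)c2cncnc2)cc1)C(F)(F)F` differs from compound 2 by pyrimidin-5-yl in place of 3-fluorophenyl on a sulfonyl sulfur. Within the data shown here, no measured step changes that ring, so none bears directly on this change, and the values of compound 1 and compound 2 show only a gap within the scatter. For compound 4 a modest weakening is expected, a 1.6-fold higher number from compound 2 to compound 4 (0.21 log units; within the scatter). Compound 4 is therefore estimated at 5500 nM, in the range 2000 nM to 15000 nM.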

Compound 4, half-maximal inhibitory concentration: > 30000 nM
Compound 4 gave a limit, no number; the forecaster's own chance of this, stated with the estimate: 10%; middle value at least 5.4-fold (0.73 log units) away from the limit.
By their numbers in this assay, from the lowest: compounds 1, 2 and 3 (each within the scatter of the next, the first and the last beyond it). At a limit, above all of these: compound 4.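

The ring on the sulfonyl sulfur, untouched by the earlier step, proves sensitive to change in this assay: pyrimidin-5-yl in place of 3-fluorophenyl gives an at least 8.8-fold higher number from compound 2 to compound 4 (0.94 log units; beyond the scatter). Even as a minimum, this exceeds the step on the ring bearing the amide, a 2.1-fold higher number from compound 1 to compound 3 (0.32 log units; beyond the scatter). Compound 4 gives a limit, not a number: the limit of > 30000 nM in this assay, at which 1 of the 4 values shown sits.

As far as these compounds go, the true value of compound 4 stays open, as does whether the step follows from the two ring nitrogens entering or from the fluorine leaving. A pyridyl group on the sulfonyl sulfur would help separate these.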